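A few compounds are considered here, and "the series" means these few. Any claim that something is new, unique, unknown or untested is made for them only; others in the source may bear on it.

Compounds measured so far:
Compound 1 `O=CCN1N=C(c2ccc3ccccc3c2)CC1c1ccco1` gives 18000 nM in a functional assay on OVCAR cells (Homo sapiens) for cytotoxicity, read by sulforhodamine B assay, with a stated time of 48 h; on this read-out lower numbers stand for stronger inhibition and higher numbers for weaker inhibition.
Compound 2 `COc1ccc(C2CC(c3ccc4ccccc4c3)=NN2CC=O)cc1` gives 5790 nM in this assay.

On these two numbers compound 2 stands lowest; its nearest neighbour is compound 1, and the step of a 3.1-fold lower number from compound 1 to compound 2 (0.49 log units; beyond the scatter) lies beyond the usual scatter. Compound 3 `O=CCN1N=C(c2ccc3ccccc3c2)CC1/C=C/c1ccccc1` has not yet been tested. It differs from compound 2 in one place: 2-phenylethenyl in place of 4-methoxyphenyl on a saturated ring carbon.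

For the measured compounds named here, only one measured step exists, and it concerns a different exchange at the same saturated ring carbon, namely the move from furan-2-yl to 4-methoxyphenyl in a 3.1-fold lower number from compound 1 to compound 2 (0.49 log units; beyond the scatter). That step was modest in size and points to the lower numbers from the 4-methoxyphenyl compound 2. Whether a 2-phenylethenyl group at this position behaves more like the furan-2-yl of compound 1 or like the 4-methoxyphenyl of compound 2 cannot be read from the data in hand. With both reference values lying within a modest span, the expectation for compound 3 is a number near that of compound 2, with no step beyond the scatter expected, as in a 1.1-fold higher number from compound 2 to compound 3 (0.05 log units; within the scatter). Compound 3 is therefore estimated at 6500 nM, within a range of 2000 nM to 20000 nM in this assay.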

Compound 3, half-maximal inhibitory concentration: 18100 nM
Compound 3: middle estimate off by 2.8-fold (0.44 log units), on the low side, and the stated range covers the measured number.
By their numbers in this assay, from the lowest: compound 2; then compounds 1 and 3 (each within the scatter of the next).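

In this assay, putting 2-phenylethenyl in place of 4-methoxyphenyl on the saturated ring carbon gives a 3.1-fold higher number from compound 2 to compound 3 (0.50 log units; beyond the scatter), although the two groups have the same count of 8 heavy atoms and each carries one six-membered aromatic ring of carbon only. Heavy-atom count and that ring therefore do not by themselves preserve the number of compound 2 at this position. The exchange of furan-2-yl for 2-phenylethenyl gives a 1.0-fold higher number from compound 1 to compound 3 (0.00 log units; within the scatter), so among the three compounds shown, only the 4-methoxyphenyl of compound 2 stands apart, with the lowest number. Nothing available explains this difference between the groups.

The compounds shown leave open whether the gap belongs to the methoxy group itself or to the 4-substituted phenyl as a whole, which a plain phenyl, a 4-hydroxyphenyl or a 4-aminophenyl at this saturated ring carbon would help to separate. Going by these compounds, it also remains open whether the same order of groups would hold if the formylmethyl group on the ring nitrogen were replaced by a longer chain or a carboxylic acid.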